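A few compounds are considered here, and "the series" means these few. Any claim that something is new, unique, unknown or untested is made for them only; others in the source may bear on it.

Going by the values given here, in a functional assay on THP-1 cells (Homo sapiens) for cytotoxicity, read by MTT assay, with a stated time of 24 h (a higher number here means a weaker inhibitor, a lower number a stronger inhibitor), compound 1 (`COc1cc(/C=C2\CN(C)C/C(=C\c3ccc(Cl)cc3)C2=O)cc(OC)c1`) gives 5860 nM, the higher of the two numbers measured so far. Among the compounds with values here, the only other measured compound, compound 2 (`COc1cc(/C=C2\CN(C)C/C(=C\c3ccc(C#N)cc3)C2=O)cc(OC)c1`), gives 940 nM. The step between them is a 6.2-fold lower number from compound 1 to compound 2 (0.79 log units; beyond the scatter). Compound 3 (`COc1cc(/C=C2\CN(C)C/C(=C\c3ccc(Cl)cc3)C2=O)cc(OC)c1OC`) keeps the chloro group of compound 1 and alters the aromatic ring carrying the methoxy groups: methoxy in place of hydrogen on an aromatic carbon. This places methoxy in place of hydrogen on an aromatic carbon, ortho to two methoxy groups and para to a large group.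

Within the data shown here, the one measured step bears on this change only indirectly. Among the measured compounds shown here, it concerns cyano in place of chloro, not the site of the new methoxy, and no measured pair tests that group. It shows only that a single substitution on compound 1 can produce a modest shift, as in a 6.2-fold lower number from compound 1 to compound 2 (0.79 log units; beyond the scatter). A step of similar or smaller size is therefore expected, and the data do not settle its direction, though a lower number is tentatively favoured. The expected step is a 1.7-fold lower number from compound 1 to compound 3 (0.22 log units; within the scatter). For compound 3 the estimate is 3500 nM, with an expected range from 1300 nM to 9000 nM.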

Compound 3, half-maximal inhibitory concentration: 7200 nM
Compound 3: middle estimate off by 2.1-fold (0.31 log units), on the low side, and the stated range covers the measured number.
By their numbers in this assay, from the lowest: compound 2; then compounds 1 and 3 (each within the scatter of the next).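

In this assay the change of methoxy in place of hydrogen on an aromatic carbon, ortho to two methoxy groups and para to a large group, gives a 1.2-fold higher number from compound 1 to compound 3 (0.09 log units; within the scatter), so compound 3 cannot be told apart from compound 1 in this assay. The earlier pair had shown only a single substitution that moved the number beyond the scatter, a 6.2-fold lower number from compound 1 to compound 2 (0.79 log units; beyond the scatter), and this pair adds that a single substitution on compound 1 need not do so: with the chloro group kept, the methoxy group can occupy this aromatic carbon without a measurable shift. Nothing available on these compounds accounts for this result.

The compounds shown leave open whether a different group on this same aromatic carbon, such as a hydroxyl group, an amine or a longer chain like ethoxy, would give a step beyond the scatter. They also leave open whether the added methoxy would give a similarly small step in the presence of the cyano group of compound 2.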